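The compounds below may be only part of what the source reports. "The series", "measured", "known", "first", "only" and "open" are said of these compounds alone.

Values in a physicochemical assay for permeability, using PAMPA (on this read-out lower numbers stand for lower permeability and higher numbers for higher permeability), for the compounds so far:
- compound 1 `Cc1oc(-c2c(Cl)cccc2Cl)nc1CN1CCC(C(=O)NCCCN2C[C@H](C)C[C@H](C)C2)CC1` - "not determined" (no result reported)
- compound 2 `Cc1oc(-c2ccc(Cl)c(Cl)c2)nc1CN1CCC(C(=O)NCCCN2C[C@H](C)C[C@H](C)C2)CC1` - 522 10^-6 cm/s
- compound 3 `Cc1oc(-c2c(Br)cccc2Br)nc1CN1CCC(C(=O)NCCCN2C[C@H](C)C[C@H](C)C2)CC1` - < 1 10^-6 cm/s (a limit of the assay, not a number)

Compound 3 has no single number on this read-out, only the limit of < 1 10^-6 cm/s in this assay, at which 1 of the 3 values shown sits, and so its place is marked by a limit alone. The next compound to be read is compound 4 `COc1cccc(Br)c1-c1nc(CN2CCC(C(=O)NCCCN3C[C@H](C)C[C@H](C)C3)CC2)c(C)o1` and its difference from compound 3 is methoxy in place of bromo on an aromatic carbon which amounts to methoxy in place of bromo on an aromatic carbon, ortho to a large group, so that 2,6-dibromophenyl becomes 2-bromo-6-methoxyphenyl. Among the measured compounds shown here, one measured step bears on this, namely an at least 520-fold lower number from compound 2 to compound 3 (2.71 log units; beyond the scatter) and it is large. That step brought in 2,6-dibromophenyl in place of 3,4-dichlorophenyl, whereas compound 4 retains one of the two bromo groups of compound 3. For the measured compounds named here, no measured step tests methoxy in place of bromo directly. The expectation rests on compound 3, whose < 1 10^-6 cm/s is a limit, and a low reading is expected to persist. The expected move is an at least 3.0-fold higher number from compound 3 to compound 4 (0.47 log units; beyond the scatter) in this assay and it is expected to be upward, if anything, and far smaller than the measured step. For compound 4 the estimate is 3 10^-6 cm/s with an expected range from 0.5 10^-6 cm/s to 40 10^-6 cm/s and a real chance of a limit instead of a number.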

Compound 4, apparent permeability: 245 10^-6 cm/s
Estimate against measurement, compound 4: 82-fold (1.91 log units) below; measured number outside the range, above it.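

In this assay, putting methoxy in place of one bromo on this aromatic carbon, ortho to a large group, gives an at least 240-fold higher number from compound 3 to compound 4 (2.38 log units; beyond the scatter), so the low reading of compound 3 does not extend to a compound that keeps one of its two bromo groups. Compound 3 gives < 1 10^-6 cm/s, which is a limit of the assay and not a number, so the true size of this step cannot be fixed: the limit of < 1 10^-6 cm/s in this assay, at which 1 of the 4 values shown sits. The 2-bromo-6-methoxyphenyl group also stays only a modest step from the 3,4-dichlorophenyl group, with a 2.1-fold lower number from compound 2 to compound 4 (0.33 log units; beyond the scatter), whereas an at least 520-fold lower number from compound 2 to compound 3 (2.71 log units; beyond the scatter) is large, so the sharp fall does not follow from leaving the 3,4-dichlorophenyl group as such.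

As far as these compounds go, whether the low reading needs both bromo groups remains open, as does whether a second methoxy, a fluoro or an amine in place of the remaining bromo would keep the number near that of compound 4. The compounds shown also do not explain the effect of methoxy here, and they test this change in only this one setting.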